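The source may hold more compounds than are shown below. What is called first, only, known or untested is meant among the compounds shown, and "the series" means these compounds.

Measured so far:
- compound 1 `COC(=O)c1scc(-c2ccc(NC(=O)c3cccc(C(F)(F)F)c3)cc2)c1OC` gives 24600 nM in the series
- compound 2 `COC(=O)c1scc(-c2ccc(NC(=O)c3cccc(OC(F)(F)F)c3)cc2)c1OC` gives 7540 nM in the series

Both numbers come from a functional assay on MDA-MB-231 cells (Homo sapiens) for antiproliferative activity, read by MTT assay, with a stated time of 24 h (on this read-out lower numbers stand for stronger inhibition and higher numbers for weaker inhibition), and compound 1 holds the higher of them. Compound 3 `COC(=O)c1scc(-c2ccc(NC(=O)c3ccc(C#N)nc3)cc2)c1OC`, not yet measured, carries 6-cyanopyridin-3-yl in place of 3-(trifluoromethyl)phenyl on a carbonyl carbon. The counted difference 6-cyanopyridin-3-yl in place of 3-(trifluoromethyl)phenyl on a carbonyl carbon is the whole change.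

For the measured compounds named here, the only measured step bearing on it is a 3.3-fold lower number from compound 1 to compound 2 (0.51 log units; beyond the scatter) for trifluoromethoxy in place of trifluoromethyl on an aromatic carbon, a modest one. That step alters a substituent on the group that compound 3 replaces whole, so it gives a scale but no direction. A step of similar or smaller size is expected in this assay. As far as these compounds go, a lower number is slightly favoured from the position of compound 1 at 24600 nM and the direction stays open. The expected move is a 1.5-fold lower number from compound 1 to compound 3 (0.19 log units; within the scatter) and no more than that is claimed. For compound 3 the estimated value is 16000 nM with an expected range from 5000 nM to 50000 nM and nothing tighter is supported.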

Compound 3, half-maximal inhibitory concentration: 28500 nM
Beside the measured number, compound 3's estimate is 1.8-fold (0.25 log units) below it; the range from low to high includes it.
By their numbers in this assay, from the lowest: compound 2; then compounds 1 and 3 (each within the scatter of the next).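

In this assay, replacing the whole aryl group on the carbonyl carbon gives a 1.2-fold higher number from compound 1 to compound 3 (0.06 log units; within the scatter), so this place accepts a ring with a hetero atom and a nitrile with no change beyond the scatter. The earlier step altered only a substituent on 3-(trifluoromethyl)phenyl, whereas this one shows that neither the trifluoromethyl group nor a ring of carbon only is needed to keep a number in this range, even though the entering group carries hydrogen-bond acceptors and the leaving group carries none. No available data give a reason for this result.

As far as these compounds go, the nitrile and the ring nitrogen enter together in compound 3, so what each does alone stays open. Also open, from the compounds shown here alone, is how a carboxylic acid or an amine in place of the nitrile in 6-cyanopyridin-3-yl would read in this assay.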